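From methoxy to 2,2-difluoroethoxy on the shared core

The source may hold more compounds than are shown below. What is called first, only, known or untested is meant among the compounds shown, and "the series" means these compounds.

In an ADME assay on S9 fraction from liver (Rattus norvegicus) for metabolic stability, with a stated time of 1 h (on this read-out higher numbers stand for a more stable compound and lower numbers for a less stable compound), compound 1 `N#Cc1cnc(NCc2cncnc2-c2ccccc2)cc1N[C@H]1CC[C@@H](O)CC1` gives 78% and compound 2 `COc1ncncc1CNc1cc(N[C@H]2CC[C@@H](O)CC2)c(C#N)cn1` gives 89%. Among the compounds with values here, compound 2 therefore holds the higher of the only two numbers available. Within the data shown here, the single measured step between them is a number 11 percentage points higher from compound 1 to compound 2 (beyond the scatter), with methoxy in place of phenyl on an aromatic carbon.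

Compound 3 `N#Cc1cnc(NCc2cncnc2OCC(F)F)cc1N[C@H]1CC[C@@H](O)CC1` keeps the rest of compound 2 and alters only that methoxy: difluoromethyl in place of hydrogen on a saturated chain carbon bound to an oxygen on an aromatic ring. This is difluoromethyl in place of hydrogen on a saturated chain carbon bound to an oxygen on an aromatic ring, which turns methoxy into 2,2-difluoroethoxy.

Among the measured compounds shown here, only the step from compound 1 bears on this change, and it is a modest one involving a different pair of groups. For the measured compounds named here, no measured pair shows what difluoromethyl does here. With compound 2 at 89%, little of the scale remains above it, so a small fall is the more likely direction. The expected change is a number 6 percentage points lower from compound 2 to compound 3 (within the scatter). For compound 3 the estimated value is 83%, with an expected range from 68% to 95%.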

Compound 3, percent of the compound remaining: 79%
The estimate for compound 3 lay 4 percentage points above the measured number, and the stated range covers the measured number.
By their numbers in this assay, from the lowest: compounds 1, 3 and 2 (each within the scatter of the next, the first and the last beyond it).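

In this assay, within the data shown here, the change from methoxy to 2,2-difluoroethoxy gives a number 10 percentage points lower from compound 2 to compound 3 (within the scatter) and so does not move the compound clear of the scatter, which is the first reading of a change on the saturated chain carbon bound to an oxygen on an aromatic ring. The comparison with the phenyl compound reads a number 1 percentage points higher from compound 1 to compound 3 (within the scatter) and also stays inside the scatter. Among these compounds, compound 3 therefore cannot be told apart from either neighbour, even though the two earlier compounds stand apart by a number 11 percentage points higher from compound 1 to compound 2 (beyond the scatter) and remain the only pair separated at this place. No supporting measurement is available to explain why these numbers fall as they do.

An ethoxy group at this place would separate the contribution of the longer chain from that of the two fluorine atoms, and the compounds shown leave that distinction open. They also leave open how an amine, or a 2,2,2-trifluoroethoxy group with one further fluorine atom, would read in this assay on the shared core.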